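Swapping a Fused Ring for a Small Pyrrole

The source may hold more compounds than are shown below. What is called first, only, known or untested is meant among the compounds shown, and "the series" means these compounds.

Compound 2 `O=c1nc(NCc2ccc3c(c2)OCCO3)sc2c([N+](=O)[O-])cc(C(F)(F)F)cc12` was tested in an ADME assay on HeLa cells (Homo sapiens) for cytotoxicity, with a stated time of 72 h (on this read-out higher numbers stand for lower toxicity in this test and lower numbers for higher toxicity in this test), where compound 2 gives 41000 nM. For the measured compounds named here, that is the only plain number in this assay so far. Compound 1 `O=c1nc(N2CCC(c3ccccc3)CC2)sc2c([N+](=O)[O-])cc(C(F)(F)F)cc12` gives > 50000 nM, which is a limit of the assay rather than a number (the limit of > 50000 nM in this assay, at which 1 of the 2 values shown sits). Compound 3 `Cc1ccc(CNc2nc(=O)c3cc(C(F)(F)F)cc([N+](=O)[O-])c3s2)n1C` is not yet measured. It differs from compound 2 in one place: 1,5-dimethyl-1H-pyrrol-2-yl in place of 2,3-dihydro-1,4-benzodioxin-6-yl on a saturated chain carbon bound to a nitrogen on an aromatic ring. Going by the values given here, no pair of measured compounds differs in a single place, so no step size is known here. The expected step is a 1.0-fold lower number from compound 2 to compound 3 (0.01 log units; within the scatter), nothing beyond the usual scatter. Compound 3 is therefore expected to give about 40000 nM, somewhere between 15000 nM and 100000 nM.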

Compound 3, half-maximal cytotoxic concentration: 48000 nM
Compound 3: the middle estimate sits 1.2-fold (0.08 log units) below what was measured; low and high end bracket the measured number.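

In this assay, for the compounds shown here, this is the first comparison of two compounds that differ in one place, and it gives a 1.2-fold higher number from compound 2 to compound 3 (0.07 log units; within the scatter). On the saturated chain carbon bound to a nitrogen on an aromatic ring, a single five-membered aromatic ring can therefore stand in for a group of two rings without a change beyond the scatter in this test. Compound 1 remains a limit of the assay, not a number: the limit of > 50000 nM in this assay, at which 1 of the 3 values shown sits.

From the compounds shown here alone, whether a carboxylic acid or an amine at this place would shift the number beyond the scatter remains open.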